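Methoxy in Place of Methyl: Compound 3 to Compound 4

This account rests on a few compounds, and the source may have more. Where it says the series, first, only, none or still open, it means among the compounds named here.

Measured in a functional assay on MCF7 cells (Homo sapiens) for antiproliferative activity, read by trypan blue exclusion, with a stated time of 24 h; a lower number here means a stronger inhibitor, a higher number a weaker inhibitor:
compound 1 `O=C1NC(=O)/C(=C/c2cn(Cc3ccc(Cl)cc3)c3ccccc23)N1`: 21400 nM
compound 2 `O=C1NC(=O)/C(=C/c2cn(Cc3ccccc3)c3ccc(Cl)cc23)N1`: 9200 nM
compound 3 `Cc1ccc2c(c1)c(/C=C1\NC(=O)NC1=O)cn2Cc1ccccc1`: 5200 nM

Compound 3 has the lowest number of the three; compound 2 lies within the scatter of it, while compound 1 has a higher number, beyond the scatter. Compound 4 `COc1ccc2c(c1)c(/C=C1\NC(=O)NC1=O)cn2Cc1ccccc1` differs from compound 3 in one place: methoxy in place of methyl on an aromatic carbon. Within the data shown here, no measured pair swaps these two groups. The nearest comparison is a change of one small group on an aromatic carbon, a 1.8-fold lower number from compound 2 to compound 3 (0.25 log units; within the scatter), which stayed within the scatter. On that basis no step beyond the scatter is expected for compound 4, whose number in this assay is estimated as 5500 nM, with a range of 2000 nM to 15000 nM, meaning an expected step of a 1.1-fold higher number from compound 3 to compound 4 (0.02 log units; within the scatter).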

Compound 4, half-maximal inhibitory concentration: 7200 nM
Beside the measured number, compound 4's estimate is 1.3-fold (0.12 log units) below it; measured number inside the range.
By their numbers in this assay, from the lowest: compounds 3, 4 and 2 (each within the scatter of the next); then compound 1.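

In this assay, this position on the shared core now carries chloro, methyl and methoxy, and the three stay within the scatter of one another (a 1.4-fold higher number from compound 3 to compound 4 (0.14 log units; within the scatter); a 1.3-fold lower number from compound 2 to compound 4 (0.11 log units; within the scatter)). Methoxy adds an oxygen and a hydrogen-bond acceptor that methyl lacks, yet the number does not move beyond the scatter. Nothing available explains this flat result. From the compounds shown here alone, whether an amine or a carboxylic acid at this position would give a step beyond the scatter remains open.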